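Urea-linked ester on a nucleoside sulfonate: expected cytotoxicity

The source may hold more compounds than are shown below. What is called first, only, known or untested is meant among the compounds shown, and "the series" means these compounds.

Measured in a functional assay on HEL cells (Homo sapiens) for cytotoxicity, read by microscopy; on this read-out higher numbers stand for lower toxicity in this test and lower numbers for higher toxicity in this test:
- compound 1 `Cc1cn([C@@H]2O[C@H](CO[Si](C)(C)C(C)(C)C)[C@@]3(OS(=O)(=O)C=C3NCC(=O)O)[C@H]2O[Si](C)(C)C(C)(C)C)c(=O)n(C)c1=O` gives 300000 nM
- compound 2 `COC(=O)CNC1=CS(=O)(=O)O[C@@]12[C@@H](CO[Si](C)(C)C(C)(C)C)O[C@@H](n1cc(C)c(=O)n(C)c1=O)[C@@H]2O[Si](C)(C)C(C)(C)C` gives >= 400000 nM, which is a limit of this assay and not a number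
- compound 3 `C=C(C)C(=O)NC(=O)NC1=CS(=O)(=O)O[C@@]12[C@@H](CO[Si](C)(C)C(C)(C)C)O[C@@H](n1cc(C)c(=O)n(C)c1=O)[C@@H]2O[Si](C)(C)C(C)(C)C` gives 20000 nM

Among the numbers shown, compound 1 has the highest, and compound 3 sits nearest to it with a 15-fold lower number from compound 1 to compound 3 (1.18 log units; beyond the scatter). Compound 2 sits at a limit (the limit of >= 400000 nM in this assay, at which 1 of the 3 values shown sits). Compound 4 `CCOC(=O)CNC(=O)NC1=CS(=O)(=O)O[C@@]12[C@@H](CO[Si](C)(C)C(C)(C)C)O[C@@H](n1cc(C)c(=O)n(C)c1=O)[C@@H]2O[Si](C)(C)C(C)(C)C` differs from compound 1 by ((ethoxycarbonyl)methyl)carbamoyl in place of carboxymethyl on an amine nitrogen. Among the measured compounds shown here, two measured steps bear on this change. Turning the carboxymethyl into a carbamoyl-type group, as in a 15-fold lower number from compound 1 to compound 3 (1.18 log units; beyond the scatter), gave a large drop in the number. Capping the acid as an ester, as in an at least 1.3-fold higher number from compound 1 to compound 2 (0.12 log units; that floor lies within the scatter), stayed within the scatter. Compound 4 combines a urea with an ester, so a step below that of compound 3 but in the same direction is expected, a 3.0-fold lower number from compound 1 to compound 4 (0.48 log units; beyond the scatter). Compound 4 is therefore estimated at 100000 nM, with a range from 25000 nM to 400000 nM.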

Compound 4, minimum cytotoxic concentration: 16000 nM
Estimate against measurement, compound 4: 6.3-fold (0.80 log units) above; the whole stated range lies above it.
By their numbers in this assay, from the lowest: compounds 4 and 3 (each within the scatter of the next); then compound 1. At a limit, above all of these: compound 2.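

In this assay the urea chain with its ethyl ester gives a 19-fold lower number from compound 1 to compound 4 (1.27 log units; beyond the scatter) and so higher toxicity in this test, which shows that an ester at the end of the chain does not cancel the drop seen with the other carbamoyl-type group. The two ureas cannot be told apart, with a 1.3-fold lower number from compound 3 to compound 4 (0.10 log units; within the scatter) even though their end groups, (ethoxycarbonyl)methyl and (1-methylethenyl)carbonyl, differ. The step of an at least 25-fold lower number from compound 2 to compound 4 (1.39 log units; beyond the scatter) is also large, but compound 2 gives a limit and not a number: the limit of >= 400000 nM in this assay, at which 1 of the 4 values shown sits.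

From the compounds shown here alone, a urea ending in a free carboxylic acid, or in a plain ethyl chain without an ester, remains open. So does the effect of a longer chain between the urea and the ester.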